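A few compounds are considered here, and "the series" means these few. Any claim that something is new, unique, unknown or untested is made for them only; others in the source may bear on it.

Measured in an ADME assay on RWPE-1 cells (Homo sapiens) for inhibition, read by MTT assay, with a stated time of 24 h; a higher number here means a weaker inhibitor, a lower number a stronger inhibitor:

- Compound 1 `CCOC1c2cc(OCc3cc(C)cc(C)c3)c(OCc3cc(C)cc(C)c3)cc2CCN1C(=O)OC(C)(C)C` gives > 20000 nM.
- Compound 2 `C/C=C/C(=O)CC1c2cc(OCc3cc(C)cc(C)c3)c(OCc3cc(C)cc(C)c3)cc2CCN1C(=O)OC(C)(C)C` gives > 20000 nM.
- Compound 3 `CC[C@@H]1C[C@H](O)C/C=C(/C)[C@H]2c3cc(OCc4ccccc4)c(OCc4ccccc4)cc3CCN12` gives > 20000 nM.

Each of these entries is a limit of the assay and not a number. Going by the values given here, the series so far therefore offers (the limit of > 20000 nM in this assay, at which 3 of the 3 values shown sit), and it holds no graded value. Compound 2 stands at this limit with the other two compounds, so its place among them cannot be ranked.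

The next compound is compound 4 `Cc1cc(C)cc(COc2cc3c(cc2OCc2cc(C)cc(C)c2)CN(C(=O)OC(C)(C)C)CC3)c1`. The change is hydrogen in place of ((prop-1-en-1-yl)carbonyl)methyl on a saturated ring carbon.

Among the compounds with values here, the one measured step that bears on this place is a step that the two limits leave unreadable from compound 1 to compound 2. It swaps ethoxy for the same ((prop-1-en-1-yl)carbonyl)methyl on that carbon, and both ends of it remain limits. It gives no size to carry over, and it gives no direction.

The expectation for compound 4 leans on compound 2, whose > 20000 nM is a limit. No readable change in this assay is expected, and a further limit is the most likely report. The expected step, a step that the limit leaves unreadable from compound 2 to compound 4, is only a rough estimate since it starts from a limit. For compound 4 the estimated value is 25000 nM, with an expected range from 10000 nM to 60000 nM.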

Compound 4, half-maximal inhibitory concentration: > 20000 nM
Compound 4 ended at the assay's limit (the forecaster's own chance of this, stated with the estimate: 80%); the middle value is on the limit's open side.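

In this assay compound 4 gives > 20000 nM, which is a limit and not a number. The steps to compound 4 from compound 1 and from compound 2 therefore cannot be read, and the series stays ungraded: the limit of > 20000 nM in this assay, at which 4 of the 4 values shown sit.

The compounds shown leave open whether any change to the shared core would give a graded value in this assay.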